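This account rests on a few compounds, and the source may have more. Where it says the series, first, only, none or still open, it means among the compounds named here.

Three compounds have been assessed in a functional assay on A2780 cells (Homo sapiens) for inhibition, with a stated time of 72 h; on this read-out lower numbers stand for stronger inhibition and higher numbers for weaker inhibition. Compound 1 `CC1(C)CC(C)(C)c2cc(NC(=O)Nc3ccc(C(F)(F)F)cc3)ccc2O1` gave 3600 nM in this assay. Compound 3 `CC1(C)CC(C)(C)c2cc(NC(=O)Nc3ccc(OC(F)(F)F)cc3)ccc2O1` gave 4560 nM, and compound 2 `CC1(C)CCOc2ccc(NC(=O)Nc3ccc(OC(F)(F)F)cc3)cc21` gave 3500 nM; all three numbers lie within the scatter of one another, so none of them can be set apart from the rest. For the measured compounds named here, the only counted change between measured compounds is trifluoromethyl in place of trifluoromethoxy on an aromatic carbon, and it made a 1.3-fold lower number from compound 3 to compound 1 (0.10 log units; within the scatter). Compound 2 and compound 3 both carry trifluoromethoxy but rest on different cores; the difference between the two cores is not broken down here. Compound 4 `CC1(C)CCOc2ccc(NC(=O)Nc3ccc(C(F)(F)F)cc3)cc21` has not yet been measured. It arises from compound 2 by trifluoromethyl in place of trifluoromethoxy on an aromatic carbon, the same change that leads from compound 3 to compound 1, made at a place described in the same words. Because that change gave a 1.3-fold lower number from compound 3 to compound 1 (0.10 log units; within the scatter), a step of about the same size is expected here, a 1.3-fold lower number from compound 2 to compound 4 (0.11 log units; within the scatter). On that basis compound 4 is expected to show 2700 nM in this assay, with a likely range from 1400 nM to 5500 nM.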

Compound 4, half-maximal inhibitory concentration: 5000 nM
Beside the measured number, compound 4's estimate is 1.9-fold (0.27 log units) below it; measured number inside the range.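

In this assay, trifluoromethyl in place of trifluoromethoxy on an aromatic carbon now gives a 1.4-fold higher number from compound 2 to compound 4 (0.15 log units; within the scatter). Set beside the earlier step, the result on the second core does not differ from that on the first, even though the printed numbers run in opposite directions: the same change on two cores in this assay, a 1.3-fold lower number (0.10 log units; within the scatter) from compound 3 to compound 1 and a 1.4-fold higher number (0.15 log units; within the scatter) from compound 2 to compound 4, 1.8-fold (0.26 log units) apart, within the scatter of two such steps. This shows that the change stays within the scatter on both cores, so carrying it from one core to the other holds up in the plain sense that neither core sets the read-out apart; it does not show that the change has a real effect of either sign, or that the two cores respond identically, and two steps this small cannot settle either point.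

The compounds shown leave open whether another group in that place, such as a nitrile, an amine or a carboxylic acid, would give a step beyond the scatter. They also leave open whether a longer chain on the core would do so.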